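Moving a Bromine Around the Phenyl Ring

The source may hold more compounds than are shown below. What is called first, only, known or untested is meant among the compounds shown, and "the series" means these compounds.

Compound 2 `CNC(=O)c1cc(Oc2ccc3nc(Nc4ccccc4Br)ncc3c2)ccn1` is tested in an ADME assay on Caco-2 cells (Homo sapiens) for permeability, in the apical to basolateral direction; a higher number here means that the compound crosses the layer faster, a lower number that the compound crosses the layer more slowly. There compound 2 gives only the limit < 1 10^-6 cm/s, not a number. Its companions sit the same way. Compound 1 `CNC(=O)c1cc(Oc2ccc3nc(Nc4ccccc4)ncc3c2)ccn1` is at the limit < 1 10^-6 cm/s in this assay. Compound 3 `CNC(=O)c1cc(Oc2ccc3nc(Nc4cccc(C(C)C)c4)ncc3c2)ccn1` is likewise at the limit < 1 10^-6 cm/s. The steps a step that the two limits leave unreadable from compound 1 to compound 2, a step that the two limits leave unreadable from compound 1 to compound 3 and a step that the two limits leave unreadable from compound 2 to compound 3 therefore cannot be read; all three values rest on (the limit of < 1 10^-6 cm/s in this assay, at which 3 of the 3 values shown sit). Compound 4 `CNC(=O)c1cc(Oc2ccc3nc(Nc4ccc(Br)cc4)ncc3c2)ccn1` differs from compound 2 by 4-bromophenyl in place of 2-bromophenyl on a nitrogen on an aromatic ring. Every measured step stays hidden behind the limit; none of them bears readably on this change, and nothing in the three measured compounds points to a move beyond the scatter. Compound 4 is therefore expected to remain near the limit as well, with an estimated value of 0.6 10^-6 cm/s and a range from 0.2 10^-6 cm/s to 1.5 10^-6 cm/s. The step that the limit leaves unreadable from compound 2 to compound 4 that this estimate implies is expected to be small.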

Compound 4, apparent permeability: < 1 10^-6 cm/s
Compound 4: only a limit was reported; the forecaster's own chance of this, stated with the estimate: 75%; the middle value does not contradict the limit.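

Compound 4, like compound 1, compound 2 and compound 3, gives only a limit in this assay, not a number, and none of its steps to them can be read: the limit of < 1 10^-6 cm/s in this assay, at which 4 of the 4 values shown sit. The compounds shown leave open whether 4-bromophenyl in place of 2-bromophenyl makes any difference to the read-out.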